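Returning the amide to a methylamine in a piperazine series

A few compounds are considered here, and "the series" means these few. Any claim that something is new, unique, unknown or untested is made for them only; others in the source may bear on it.

Measured so far:
compound 1 `CCN[C@H](c1cc(C(F)(F)F)ccc1N1CCN(C(=O)CCc2ccc(Cl)cc2Cl)CC1)C(C)CC` — 92 nM
compound 2 `CCC(C)[C@H](NC(C)=O)c1cc(C(F)(F)F)ccc1N1CCN(C(=O)CCc2ccc(Cl)cc2Cl)CC1` — 360 nM

In an assay on HEK293 cells for displacement of a labelled ligand from Melanocortin receptor 4 (Homo sapiens) (a higher number here means a weaker inhibitor, a lower number a stronger inhibitor), compound 2 gives 360 nM, the higher of the two numbers; compound 1 lies a 3.9-fold higher number from compound 1 to compound 2 (0.59 log units; beyond the scatter) away. Compound 3 `CN[C@@H](CC(C)C)c1cc(C(F)(F)F)ccc1N1CCN(C(=O)CCc2ccc(Cl)cc2Cl)CC1` differs from compound 2 by 3-methyl-1-(methylamino)butyl in place of 1-acetamido-2-methylbutyl on an aromatic carbon. For the measured compounds named here, the only measured step that bears on it is the one from compound 1 to compound 2, a 3.9-fold higher number from compound 1 to compound 2 (0.59 log units; beyond the scatter), which the change to compound 3 largely reverses by restoring a secondary amine; the shorter alkyl on nitrogen and the altered side chain have no measured precedent. Compound 3 is therefore expected to give 110 nM, with a range of 35 nM to 400 nM, a step of a 3.3-fold lower number from compound 2 to compound 3 (0.51 log units; beyond the scatter).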

Compound 3, inhibition constant: 1900 nM
For compound 3 the middle estimate is 17-fold (1.24 log units) below the measured one; the whole stated range lies below it.
By their numbers in this assay, from the lowest: compound 1; then compound 2; then compound 3.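

In this assay, the secondary amine of 3-methyl-1-(methylamino)butyl does not by itself bring back a low number at this aromatic carbon: the change gives a 5.3-fold higher number from compound 2 to compound 3 (0.72 log units; beyond the scatter), and between the two amines there is a 21-fold higher number from compound 1 to compound 3 (1.31 log units; beyond the scatter). Having a secondary amine here is therefore not enough, and the change from compound 1 alters the alkyl on nitrogen and the carbon side chain together. Nothing shown explains this result.

The compounds shown leave open how much of the step belongs to each of those two parts. They also leave open how a primary amine or a longer chain on nitrogen would read at this position.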